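Compound 4: what replaces the hydroxypyrrolidine amide?

This account rests on a few compounds, and the source may have more. Where it says the series, first, only, none or still open, it means among the compounds named here.

Measured in a physicochemical assay for solubility, read by HPLC, using the shake flask method, in phosphate buffer, with a stated time of 2 h, at pH 6.5 (a higher number here means a more soluble compound, a lower number a less soluble compound), so far
- Compound 1 (`NC(=O)c1ccc(-c2cnc(N)c(-c3ccc(C(F)(F)F)cc3)n2)cc1`) gives < 5000 nM as a limit of the assay
- Compound 2 (`Nc1ncc(-c2ccc(C(=O)N3CCC(O)C3)cc2)nc1-c1ccc(C(F)(F)F)cc1`) gives 77000 nM in solution
- Compound 3 (`Nc1ccc(-c2nc(-c3ccc(S(=O)(=O)C4CC4)cc3)cnc2N)cn1`) gives 13000 nM in solution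

Compound 2 at 77000 nM stands highest of the numbers, and compound 3 at 13000 nM lies below it, beyond the scatter. Compound 4 (`Nc1ncc(-c2ccc(C(=O)O)cc2)nc1-c1ccc(C(F)(F)F)cc1`) carries hydroxy in place of 3-hydroxypyrrolidin-1-yl on a carbonyl carbon. One measured change falls at this place: an at least 15-fold higher number from compound 1 to compound 2 (1.18 log units; beyond the scatter) is large and beyond the scatter. That step starts from a limit, not a number (the limit of < 5000 nM in this assay, at which 1 of the 3 values shown sits). It shows that the group on this carbonyl carbon can move the number far, yet hydroxy has not been measured there, so the direction remains uncertain. A small fall within the scatter is the central expectation in this assay, with wide margins. The estimate means a 1.3-fold lower number from compound 2 to compound 4 (0.11 log units; within the scatter) as the expected step here. Compound 4 is expected at 60000 nM within an estimated range of 8000 nM to 300000 nM for now.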

Compound 4, solubility: 95000 nM
Beside the measured number, compound 4's estimate is 1.6-fold (0.20 log units) below it; the measured number falls inside the stated range.
By their numbers in this assay, from the lowest: compound 3; then compounds 2 and 4 (each within the scatter of the next). At a limit, below all of these: compound 1.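

In this assay, hydroxy in place of 3-hydroxypyrrolidin-1-yl on this carbonyl carbon gives a 1.2-fold higher number from compound 2 to compound 4 (0.09 log units; within the scatter), so two groups with very different heavy-atom counts, only one of them with a ring, cannot be told apart here. Hydroxy in place of amino at the same place gives an at least 19-fold higher number from compound 1 to compound 4 (1.27 log units; beyond the scatter), which shows that the ring is not needed for a large step from compound 1. The value of compound 1 is a limit and not a number: the limit of < 5000 nM in this assay, at which 1 of the 4 values shown sits.

The compounds shown still do not tell why amino stands apart from the other two groups at this place. A plain pyrrolidin-1-yl without its hydroxy, or a methoxy forming a methyl ester, on the same carbonyl carbon would test whether the hydroxy group in both compounds matters.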